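Hydroxy for amino at the cytotoxicity limit

A few compounds are considered here, and "the series" means these few. Any claim that something is new, unique, unknown or untested is made for them only; others in the source may bear on it.

Among the compounds with values here, in a functional assay on Vero cells (Chlorocebus sabaeus) for cytotoxicity (on this read-out higher numbers stand for weaker inhibition and lower numbers for stronger inhibition), compound 1 `O=c1ccn(C2C=C(F)C(CO)O2)c(=O)[nH]1` gives 82600 nM as the only true number so far. Compound 2 `Nc1ccn([C@H]2C=C(F)[C@@H](CO)O2)c(=O)n1` reads > 100000 nM and this is a limit of the assay, not a number. Going by these compounds, compound 3 `Nc1ncnc2c1ncn2[C@H]1C=C(F)[C@@H](CO)O1` reads > 100000 nM and this too is a limit, so its exact place is unknown. The picture so far is the limit of > 100000 nM in this assay, at which 2 of the 3 values shown sit, and compound 3 is one of those two.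

Compound 4 `OC[C@H]1O[C@@H](n2cnc3c(O)ncnc32)C=C1F` has hydroxy in place of amino on an aromatic carbon of the core of compound 3: hydroxy in place of amino on an aromatic carbon. Within the data shown here, no measured pair shows this change on its own, so the expectation rests on the three values alone. In this assay no step beyond the scatter is expected, in either direction, and a further limit reading would be no surprise. The estimated step is a number no higher from compound 3 to compound 4 (the limit leaves the size open) and it stays uncertain. In this assay the expected value for compound 4 is 100000 nM with an estimated range from 40000 nM to 200000 nM.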

Compound 4, half-maximal inhibitory concentration: > 100000 nM
Compound 4 was reported as a limit; the forecaster's own chance of this, stated with the estimate: 75%; the middle value sits exactly at the limit.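

Within the data shown here, compound 3 and compound 4 both stand at a limit of the assay, not at a number, so no step between them can be read: the limit of > 100000 nM in this assay, at which 3 of the 4 values shown sit. The compounds shown leave open whether hydroxy in place of amino on an aromatic carbon changes cytotoxicity at all.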